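The compounds below may be only part of what the source reports. "The series", "measured", "known", "first", "only" and "open" are said of these compounds alone.

For the measured compounds named here, in a functional assay on K562 cells (Homo sapiens) for inhibition, read by trypan blue exclusion, with a stated time of 72 h (on this read-out higher numbers stand for weaker inhibition and lower numbers for stronger inhibition), compound 1 `Cn1c(=O)c(S(=O)(=O)c2ccc(Cl)cc2Cl)cc2cnc(Nc3ccc4[nH]ccc4c3)nc21` gives 1000 nM and compound 2 `Cn1c(=O)c(S(=O)(=O)Cc2ccc(F)cc2F)cc2cnc(Nc3ccc4[nH]ccc4c3)nc21` gives 1000 nM, so compound 2 stands level with its only neighbour. Compound 3 `Cn1c(=O)c(S(=O)(=O)Cc2ccc(F)cc2)cc2cnc(Nc3ccc4[nH]ccc4c3)nc21` has hydrogen in place of fluoro on an aromatic carbon, ortho to a large group: hydrogen in place of fluoro on an aromatic carbon. Going by the values given here, the only measured evidence is indirect, a different change at the same sulfonyl sulfur, which shows no change at the digits printed from compound 1 to compound 2 (within the scatter). On that evidence, no shift beyond the scatter is expected in this assay, and the expected step is no change at the digits printed from compound 2 to compound 3 (within the scatter). The estimate for compound 3 is 1000 nM, with an expected range of 400 nM to 2500 nM.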

Compound 3, half-maximal inhibitory concentration: 30000 nM
Compound 3: the middle estimate sits 30-fold (1.48 log units) below what was measured, outside the stated range (above it).
By their numbers in this assay, from the lowest: compounds 1 and 2 (each within the scatter of the next); then compound 3.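

In this assay, taking away the fluoro ortho to a large group gives a 30-fold higher number from compound 2 to compound 3 (1.48 log units; beyond the scatter) and so shows that this position is sensitive, which the earlier pair, with its flat step at the sulfonyl sulfur, did not reveal. The 4-fluorobenzyl group likewise falls behind the 2,4-dichlorophenyl group, with a 30-fold higher number from compound 1 to compound 3 (1.48 log units; beyond the scatter) across that change. Nothing measured here bears on why the single fluoro matters so much. As far as these compounds go, whether a methyl or a methoxy group at this place would match fluoro or hydrogen remains open. So does whether the fluoro group in the 4-fluorobenzyl group matters.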